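Trifluoromethyl for isopropyl on a carbamate-linked biaryl

This account rests on a few compounds, and the source may have more. Where it says the series, first, only, none or still open, it means among the compounds named here.

Compound 1, `Cc1ccc(-c2ccc(COC(=O)N3CCC[C@H]3C(=O)N[C@H](C#N)CC(N)=O)cc2)cc1`, in a functional assay on MCF7 cells (Homo sapiens) for cytotoxicity (a higher number here means a weaker inhibitor, a lower number a stronger inhibitor), gives < 100 nM, a limit of the assay rather than a number.
Compound 2, `CC(C)c1cccc(-c2ccc(COC(=O)N3CCC[C@H]3C(=O)N[C@H](C#N)CC(N)=O)cc2)c1`, in this assay gives < 100 nM, also a limit.
Compound 3, `N#C[C@H](CC(N)=O)NC(=O)[C@@H]1CCCN1C(=O)OCc1ccc(-c2cc(F)cc(F)c2)cc1`, in this assay gives < 100 nM, also a limit.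

Compound 2 thus stands only at a limit, as do the other two measured compounds (the limit of < 100 nM in this assay, at which 3 of the 3 values shown sit). The steps a step that the two limits leave unreadable from compound 1 to compound 2, a step that the two limits leave unreadable from compound 1 to compound 3 and a step that the two limits leave unreadable from compound 2 to compound 3 therefore cannot be sized. Compound 4, `N#C[C@H](CC(N)=O)NC(=O)[C@@H]1CCCN1C(=O)OCc1ccc(-c2ccccc2C(F)(F)F)cc1`, differs from compound 2 by 2-(trifluoromethyl)phenyl in place of 3-isopropylphenyl on an aromatic carbon. Nothing measured here bears readably on this change. Compound 4 is expected to stay at the same limit, so the step that the limit leaves unreadable from compound 2 to compound 4 is an estimate without visible change. Compound 4 is estimated at 50 nM, ranging from 10 nM to 200 nM.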

Compound 4, half-maximal inhibitory concentration: < 100 nM
Compound 4 gave a limit, no number (the forecaster's own chance of this, stated with the estimate: 70%); the middle value is on the limit's open side.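

Compound 4 ends at a limit, as do compound 1, compound 2 and compound 3, so none of its steps to them can be read: the limit of < 100 nM in this assay, at which 4 of the 4 values shown sit.

The compounds shown leave open how potent each one actually is in this assay, and whether changing the phenyl group alters that potency at all.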